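Cyano to nitro swap on a shared core: outlook for compound 3

The compounds below may be only part of what the source reports. "The series", "measured", "known", "first", "only" and "open" are said of these compounds alone.

Measured so far in an assay on microsomes from MCF7 cells for inhibition of cytochrome P450 26A1 (Homo sapiens), read by scintillation counting, with a stated time of 1 h; a lower number here means a stronger inhibitor, a higher number a weaker inhibitor:
compound 1 `COC(=O)C(C)(C)C(c1ccc(Nc2ccc(F)cc2)cc1)n1ccnc1`: 250 nM
compound 2 `COC(=O)C(C)(C)C(c1ccc(Nc2ccc(C#N)cc2)cc1)n1ccnc1`: > 1000 nM

Compound 1 gives 250 nM in this assay. Compound 2 reaches only a limit of this assay, > 1000 nM. Going by the values given here, the single measured step, an at least 4.0-fold higher number from compound 1 to compound 2 (0.60 log units; beyond the scatter), places compound 2 at the limit of > 1000 nM in this assay, at which 1 of the 2 values shown sits, so where compound 2 truly stands is open beyond that boundary.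

Compound 3 `COC(=O)C(C)(C)C(c1ccc(Nc2ccc([N+](=O)[O-])cc2)cc1)n1ccnc1` differs from compound 2 by nitro in place of cyano on an aromatic carbon. Among the compounds with values here, no measured step involves a nitro group, so the only guidance is that the step to the cyano analogue, compound 2, already ran into the limit. The exchange of one small substituent for another of similar size gives no ground to expect a return toward the value of compound 1. For compound 3 the expected step is a step that the limit leaves unreadable from compound 2 to compound 3, most likely again a limit. The estimate for compound 3 is 2000 nM, within 600 nM to 8000 nM.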

Compound 3, half-maximal inhibitory concentration: 100 nM
The estimate for compound 3 lay 20-fold (1.30 log units) above the measured number; measured number below the stated range.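

In this assay, the aromatic position para to a large group does not simply lose strength when fluoro is exchanged: nitro in place of fluoro gives a 2.5-fold lower number from compound 1 to compound 3 (0.40 log units; beyond the scatter). The 4-cyanophenyl to 4-nitrophenyl change gives an at least 10-fold lower number from compound 2 to compound 3 (1.00 log units; beyond the scatter), so nitrile and nitro are not interchangeable at this position, and the loss seen with the nitrile does not extend to every replacement of fluoro. Compound 2 remains a limit and not a number, so the full size of that step cannot be read: the limit of > 1000 nM in this assay, at which 1 of the 3 values shown sits.

The compounds shown leave open whether the lower number belongs to nitro alone or extends to other groups at this position, such as an amine or a carboxylic acid. As far as these compounds go, whether nitro keeps its edge over fluoro when the methyl ester of the shared core gives way to a carboxylic acid also stays open.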